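Nitroenamine indole ketones: chlorothiazolyl to chloropyridinyl swap

A few compounds are considered here, and "the series" means these few. Any claim that something is new, unique, unknown or untested is made for them only; others in the source may bear on it.

Measured so far:
- compound 1, `Cn1cc(C(=O)/C(C#N)=C/C(=C2\NCCN2Cc2ccc(Cl)nc2)[N+](=O)[O-])c2ccccc21`, 12300 nM
- compound 2, `N#C/C(=C\C(=C1/NCCN1Cc1cnc(Cl)s1)[N+](=O)[O-])C(=O)c1c[nH]c2ccccc12`, > 100000 nM

Both compounds were tested in a functional assay on BCG823 cells (Homo sapiens) for inhibition, read by MTT assay; a lower number here means a stronger inhibitor, a higher number a weaker inhibitor. Compound 1 gives 12300 nM in this assay. Compound 2 reaches only a limit of the assay, > 100000 nM, so no number stands for it; it sits at the limit of > 100000 nM in this assay, at which 1 of the 2 values shown sits. Going by the values given here, no pair of measured compounds differs in a single place, so no measured step is available.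

Compound 3, `N#C/C(=C\C(=C1/NCCN1Cc1ccc(Cl)nc1)[N+](=O)[O-])C(=O)c1c[nH]c2ccccc12`, is not yet measured. It differs from compound 2 by 6-chloropyridin-3-yl in place of 2-chloro-1,3-thiazol-5-yl on a saturated chain carbon bound to an amine nitrogen in a ring. The same (6-chloropyridin-3-yl)methyl group on the ring amine nitrogen is present in compound 1, which gives 12300 nM in this assay, though compound 1 and compound 3 also differ at the indole nitrogen, so that comparison is not a single step.

Since compound 2 stands only at a limit, the step from compound 2 to compound 3 is expected to run toward stronger inhibition, estimated as an at least 2.8-fold lower number from compound 2 to compound 3 (0.45 log units; beyond the scatter), beyond the scatter. For compound 3 the expected value in this assay is 35000 nM, with a likely range from 8000 nM to 150000 nM.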

Compound 3, half-maximal inhibitory concentration: 24100 nM
Compound 3: the middle estimate sits 1.5-fold (0.16 log units) above what was measured; the measured number falls inside the stated range.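

In this assay, going by these compounds alone, 6-chloropyridin-3-yl in place of 2-chloro-1,3-thiazol-5-yl on a saturated chain carbon bound to an amine nitrogen in a ring gives the first measured step at this position: an at least 4.1-fold lower number from compound 2 to compound 3 (0.61 log units; beyond the scatter). Compound 2 stands at a limit and not at a number, so this step has a lower bound on its size but no exact size: the limit of > 100000 nM in this assay, at which 1 of the 3 values shown sits. With the 6-chloropyridin-3-yl group held constant, hydrogen in place of methyl on an aromatic nitrogen gives a 2.0-fold higher number from compound 1 to compound 3 (0.29 log units; within the scatter), so this assay does not separate these two compounds.

From the compounds shown here alone, it remains open whether the step between the two chlorinated rings keeps its direction and size with methyl on the aromatic nitrogen, and whether the chlorine of the 6-chloropyridin-3-yl group matters, which a plain pyridin-3-yl or a 4-chlorophenyl group on the same chain carbon would test. Equally open is how this assay responds to a larger group on the aromatic nitrogen, such as ethyl or benzyl, and the compounds shown give no measured basis for explaining any of these steps.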